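This account rests on a few compounds, and the source may have more. Where it says the series, first, only, none or still open, it means among the compounds named here.

Of the compounds shown here, three that share one core have been measured in an assay on lysate for inhibition of 6-phosphofructo-2-kinase/fructose-2,6-bisphosphatase 3 (Homo sapiens), with stated times of 0.5 min and 45 min; a lower number here means a stronger inhibitor, a higher number a weaker inhibitor. Compound 1 `CNC(=O)c1ccncc1Nc1cc(-c2ccc3ccn(C)c3c2)c2nccnc2c1` gives 7020 nM. Compound 2 `Cn1ccc2ccc(-c3cc(Nc4cnccc4C(=O)NCc4cncnc4)cc4nccnc34)cc21` gives 49500 nM. Compound 3 `CN1CC(NC(=O)c2ccncc2Nc2cc(-c3ccc4ccn(C)c4c3)c3nccnc3c2)CCC1=O` gives 96500 nM. Compound 3 stands at the high end of the three numbers: there was a 14-fold higher number from compound 1 to compound 3 (1.14 log units; beyond the scatter), whereas a 1.9-fold higher number from compound 2 to compound 3 (0.29 log units; within the scatter), so compound 3 and compound 2 cannot be told apart, while both sit clearly apart from compound 1, for which a 7.1-fold higher number from compound 1 to compound 2 (0.85 log units; beyond the scatter) as well.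

Compound 4 `CC(=O)N1CCC(NC(=O)c2ccncc2Nc2cc(-c3ccc4ccn(C)c4c3)c3nccnc3c2)C1` differs from compound 3 in one place: 1-acetylpyrrolidin-3-yl in place of 1-methyl-6-oxopiperidin-3-yl on an amide-type nitrogen. The two compounds have the same atoms, joined differently, and both carry a saturated ring bearing a carbonyl on the amide-type nitrogen.

Going by the values given here, none of the measured steps concerns an exchange of one such ring for another. Among the compounds with values here, the one step that changed the group on that nitrogen from a small substituent to a ring, from compound 1 to compound 3, was large, and the step from compound 2 to compound 3 lay within the scatter. Compound 3 and compound 4 are therefore expected to give numbers close to each other in this assay, with a 1.2-fold lower number from compound 3 to compound 4 (0.08 log units; within the scatter) reflecting no step beyond the scatter. Compound 4 is expected to give about 80000 nM, with a range from 30000 nM to 250000 nM.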

Compound 4, half-maximal inhibitory concentration: > 100000 nM
Compound 4 ended at the assay's limit (the forecaster's own chance of this, stated with the estimate: 25%); middle value at least 1.2-fold (0.09 log units) away from the limit.
By their numbers in this assay, from the lowest: compound 1; then compounds 2 and 3 (each within the scatter of the next). At a limit, above all of these: compound 4.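

In this assay, compound 4 stands at a limit of the assay and not at a number, > 100000 nM, and it is the only compound shown to do so: the limit of > 100000 nM in this assay, at which 1 of the 4 values shown sits. Exchanging 1-methyl-6-oxopiperidin-3-yl for 1-acetylpyrrolidin-3-yl, a change that keeps the same atoms, gives an at least 1.0-fold higher number from compound 3 to compound 4 (0.01 log units; that floor lies within the scatter), and the change from (pyrimidin-5-yl)methyl gives an at least 2.0-fold higher number from compound 2 to compound 4 (0.30 log units; that floor lies within the scatter), so neither floor separates compound 4 from the compound it is compared with. The clear step is an at least 14-fold higher number from compound 1 to compound 4 (1.15 log units; beyond the scatter), which adds a third group on the amide-type nitrogen that gives a number beyond the scatter of the methyl compound, and none of the compounds shown goes against this.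

On these data alone, how far compound 4 lies past the limit remains unknown, so whether the five-membered ring and the six-membered ring differ at this position stays open. Also open, as far as these compounds go, is whether an ethyl group, a bare hydrogen on that nitrogen, or a pyrrolidin-3-yl ring with a free amine in place of the acetyl group would give a number nearer that of compound 1.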